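The source may hold more compounds than are shown below. What is called first, only, known or untested is meant among the compounds shown, and "the series" means these compounds.

Measured so far in an ADME assay on Vero cells (Chlorocebus sabaeus) for cytotoxicity, with a stated time of 72 h; a higher number here means a weaker inhibitor, a lower number a stronger inhibitor:
compound 1 `Cc1nonc1C(=O)NC1CCCc2c1cnn2-c1ccc(C(C)(C)C)cc1` gives > 128000 nM, which is a limit of the assay.
compound 2 `Cc1nonc1C(=O)NC1CCCc2c1cnn2-c1ccc(OC(F)(F)F)cc1` gives > 128000 nM, also a limit.

Compound 2 stands at the limit, at the limit of > 128000 nM in this assay, at which 2 of the 2 values shown sit. Among the measured compounds shown here, the one measured step, a step that the two limits leave unreadable from compound 1 to compound 2, is left unreadable by the two limits. Compound 3 `Cc1nonc1C(=O)NC1CCCc2c1cnn2-c1ccc(C(F)(F)F)cc1` differs from compound 2 by trifluoromethyl in place of trifluoromethoxy on an aromatic carbon. No readable step bears on this change, so a step beyond the scatter is not expected; compound 3 is expected to sit at the limit as well, the estimated step being a number no higher from compound 2 to compound 3 (the limit leaves the size open). The estimate for compound 3 in this assay is 128000 nM, range 60000 nM to 300000 nM.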

Compound 3, half-maximal inhibitory concentration: > 128000 nM
Compound 3: only a limit was reported (the forecaster's own chance of this, stated with the estimate: 85%); the middle value lies on the limit itself.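

In this assay no step can be read among compound 1, compound 2 and compound 3, whose values are all limits of the assay. On these data alone, whether tert-butyl, trifluoromethoxy and trifluoromethyl differ at all in this assay stays open.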